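A few compounds are considered here, and "the series" means these few. Any claim that something is new, unique, unknown or untested is made for them only; others in the source may bear on it.

In a functional assay on Raji cells (Homo sapiens) for cytotoxicity, with a stated time of 72 h (a higher number here means that more compound is needed for the effect, a lower number that less compound is needed), compound 1 (`C=C[C@@](C)(/C=C/c1ccc(O)c(/C=C/C(=O)OCc2ccccc2)c1)CCC=C(C)C`) gives > 26000 nM, which is a limit of the assay and not a number. Compound 2 (`C=C[C@@](C)(/C=C/c1ccc(O)c(/C=C/C(=O)O)c1)CCC=C(C)C`) gives > 26000 nM, and this too is only a limit. Compound 2 therefore has no readable position, and the one other result beside it is also a limit: the limit of > 26000 nM in this assay, at which 2 of the 2 values shown sit. Compound 3 (`C=C[C@@](C)(/C=C/c1ccc(O)c(/C=C/c2ccc(Cl)c(Cl)c2)c1)CCC=C(C)C`) keeps the shared core but carries a new group at the end of the chain: 3,4-dichlorophenyl in place of carboxy on a double-bonded chain carbon bound to a double-bonded chain carbon. In words, this is 3,4-dichlorophenyl in place of carboxy on a double-bonded chain carbon bound to a double-bonded chain carbon. Going by the values given here, the only measured step is a step that the two limits leave unreadable from compound 1 to compound 2. Among the compounds with values here, it changes the same carboxy end, but it gives no size to carry over, and no measured compound carries the new aryl group. The expectation thus rests on the structural change alone. Any readable result would be expected to show that less compound is needed, and a further limit remains quite possible. The expected move, loosely estimated, is an at least 2.1-fold lower number from compound 2 to compound 3 (0.33 log units; beyond the scatter). For compound 3 the estimated value is 12000 nM, with an expected range of 3500 nM to 26000 nM.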

Compound 3, half-maximal effective concentration: > 26000 nM
Compound 3 ended at the assay's limit; the forecaster's own chance of this, stated with the estimate: 40%; middle value at least 2.1-fold (0.33 log units) from the limit.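

In this assay compound 3 gives > 26000 nM and this is a limit of the assay, not a number. Going by these compounds alone, no step among compound 1, compound 2 and compound 3 can be read. The compounds shown leave open how far each lies from that limit, and whether changing the carboxy end alters the result at all: the limit of > 26000 nM in this assay, at which 3 of the 3 values shown sit.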